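Replacing 4-methylpiperazin-1-yl with piperidin-1-yl on a thiocarbonyl carbon

A few compounds are considered here, and "the series" means these few. Any claim that something is new, unique, unknown or untested is made for them only; others in the source may bear on it.

Of the compounds shown here, three have been measured in an ADME assay on HEK293 cells (Homo sapiens) for inhibition, read by MTT assay, with stated times of 18 h and 4 h (a lower number here means a stronger inhibitor, a higher number a weaker inhibitor), so far. Compound 1 (`CCCOP(=O)(O)OCCSC(=S)N1CCCCC1`) gives > 100000 nM and this is a limit of the assay, not a number. Compound 2 (`CCCCCCCCOP(=O)(O)OCCSC(=S)N1CCCCC1`) gives 69000 nM as a measured number. Among the measured compounds shown here, the one measured step is an at least 1.4-fold lower number from compound 1 to compound 2 (0.16 log units; that floor lies within the scatter) and its floor stays within the scatter. Compound 3 (`CCCCCCCCCCOP(=O)(O)OCCSC(=S)N1CCN(C)CC1`) gives > 100000 nM and this too is a limit. That puts compound 3 with the limit of > 100000 nM in this assay, at which 2 of the 3 values shown sit, and leaves it without a number of its own.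

Compound 4 (`CCCCCCCCCCOP(=O)(O)OCCSC(=S)N1CCCCC1`) differs from compound 3 only on the thiocarbonyl carbon, as piperidin-1-yl in place of 4-methylpiperazin-1-yl on a thiocarbonyl carbon shows. For the measured compounds named here, no measured step covers this replacement. The step on the chain is a different change and offers only weak guidance. Going by the values given here, the nearest anchor is compound 2 at 69000 nM as the only number in the set. A modest move toward a lower number is therefore expected, and the estimated size is an at least 2.0-fold lower number from compound 3 to compound 4 (0.30 log units; that floor lies within the scatter) with a reading at the limit still possible. Compound 4 is estimated at 50000 nM within an expected range from 18000 nM to 100000 nM for now.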

Compound 4, half-maximal inhibitory concentration: 70700 nM
Compound 4: the middle estimate sits 1.4-fold (0.15 log units) below what was measured; the range from low to high includes it.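

In this assay compound 3 gives > 100000 nM, which is a limit of the assay and not a number. Piperidin-1-yl in place of 4-methylpiperazin-1-yl on the thiocarbonyl carbon, a position no earlier step had covered, gives an at least 1.4-fold lower number from compound 3 to compound 4 (0.15 log units; that floor lies within the scatter), so a measured number now appears, but the true size of the change stays unfixed. With piperidin-1-yl held at that position, ethyl on the chain gives a 1.0-fold higher number from compound 2 to compound 4 (0.01 log units; within the scatter), so these two compounds are not separated, and heptyl on the chain gives an at least 1.4-fold lower number from compound 1 to compound 4 (0.15 log units; that floor lies within the scatter), again only a floor, as is every step that starts from a limit: the limit of > 100000 nM in this assay, at which 2 of the 4 values shown sit.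

The compounds shown leave open whether another group on the thiocarbonyl carbon, such as morpholin-4-yl or an open-chain diethylamino group, would read as a number like compound 4 or stay at the limit like compound 3. They also leave open whether a longer chain than that of compound 4 would give a number set clearly apart from those of compound 2 and compound 4.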